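A few compounds are considered here, and "the series" means these few. Any claim that something is new, unique, unknown or untested is made for them only; others in the source may bear on it.

Measured compounds in a functional assay on MCF7 cells (Homo sapiens) for antiproliferative activity, read by MTT assay, with a stated time of 72 h; on this read-out higher numbers stand for weaker inhibition and lower numbers for stronger inhibition:
- compound 1 `O=c1c(CSC(=S)N2CCCC2)coc2ccccc12` gives > 25000 nM
- compound 2 `O=c1c(CSC(=S)N2CCCCC2)coc2cc(Cl)ccc12` gives 380 nM
- compound 3 `CC(C)N(C(=S)SCc1coc2ccccc2c1=O)C(C)C` gives > 30000 nM

Compound 3 stands at a limit of this assay rather than at a number; its value is the limit (the limit of > 30000 nM in this assay, at which 1 of the 3 values shown sits). Compound 1 likewise sits at a limit, namely (the limit of > 25000 nM in this assay, at which 1 of the 3 values shown sits). Only compound 2, which carries a chlorine on its core and a piperidin-1-yl group, gives a real number, and it is by far the lowest of the three.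

The change from compound 3 to compound 4 `O=c1c(CSC(=S)N2CCCCC2)coc2ccccc12` is piperidin-1-yl in place of diisopropylamino on a thiocarbonyl carbon. Going by the values given here, no measured step follows this change directly. Among the compounds with values here, the one step that starts from compound 3, a step that the two limits leave unreadable from compound 1 to compound 3, runs between two limits and tells nothing of its size. Compound 2 carries the same piperidin-1-yl group as compound 4 but also the chlorine, so its value cannot be read as a step to compound 4.

With no readable step to rest on, the expectation for compound 4 in this assay is therefore loose: a step of an at least 3.7-fold lower number from compound 3 to compound 4 (0.57 log units; beyond the scatter) is estimated, with a sizeable chance that only a limit is reported. Compound 4 is expected at 8000 nM, between 800 nM and 40000 nM.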

Compound 4, half-maximal inhibitory concentration: 1700 nM
The estimate for compound 4 lay 4.7-fold (0.67 log units) above the measured number, and the stated range covers the measured number.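

Among the compounds without chloro, compound 4 is the only one that gives a real number in this assay, and the change on the thiocarbonyl carbon brings large steps, an at least 17-fold lower number from compound 3 to compound 4 (1.24 log units; beyond the scatter) and an at least 14-fold lower number from compound 1 to compound 4 (1.16 log units; beyond the scatter). The chloro group now has a readable step of its own, since hydrogen in its place on the aromatic carbon gives a 4.5-fold higher number from compound 2 to compound 4 (0.65 log units; beyond the scatter), a modest change set against those two large steps. The step between compound 1 and compound 3 cannot be read, and the two large steps give only minimum sizes, because each of them starts from a limit of the assay, for compound 1 as follows: the limit of > 25000 nM in this assay, at which 1 of the 4 values shown sits.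

Going by these compounds, it remains open whether chloro acts the same way with pyrrolidin-1-yl or diisopropylamino on the thiocarbonyl carbon, where a real number might or might not appear. Also open, on these data alone, is how other rings on that carbon, such as morpholin-4-yl or azepan-1-yl, or other aromatic substituents, such as fluoro or methyl in place of chloro, would compare with compound 4 in this assay.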